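Urea aryl swap on a series at the tolerance ceiling

The source may report more compounds than this note shows. Statements on the series, on what has been measured and on what is new or still open speak of the compounds shown alone.

Compound 1 `O=C(Nc1cccc(-n2cc(-c3ccncc3)c(-c3ccc(Cl)c(O)c3)n2)c1)Nc1ccc(Cl)c(Cl)c1` carries the shared core with a urea closed by a 3,4-dichlorophenyl group. In a functional assay on OVCAR-5 cells (Homo sapiens) for inhibition, read by sulforhodamine B assay, with a stated time of 48 h (a higher number here means that more compound is tolerated, a lower number that less compound is tolerated), compound 1 gives > 32500 nM, which is a limit of the assay and not a number. Compound 2 `COc1cc(-c2nn(-c3cccc(NC(=O)c4ccc(Cl)c(C(F)(F)F)c4)c3)cc2-c2ccncc2)ccc1Cl` and compound 3 `COc1cc(-c2nn(-c3cccc(NC(=O)c4ccccc4)c3)cc2-c2ccncc2)ccc1Cl` carry an amide in place of the urea. In this assay compound 2 gives > 32500 nM, again a limit. In this assay compound 3 gives > 100000 nM, also a limit. Within the data shown here, the single step between measured compounds that differ in one place, a step that the two limits leave unreadable from compound 2 to compound 3, lies unreadable between two limits. Compound 1 therefore stands where every measured compound stands, at the limit of > 32500 nM in this assay, at which 2 of the 3 values shown sit, or (the limit of > 100000 nM in this assay, at which 1 of the 3 values shown sits), with nothing resolved between them.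

Compound 4 `O=C(Nc1cccc(-n2cc(-c3ccncc3)c(-c3ccc(Cl)c(O)c3)n2)c1)Nc1cccc(C(F)(F)F)c1` differs from compound 1 by 3-(trifluoromethyl)phenyl in place of 3,4-dichlorophenyl on an amide-type nitrogen. Among the measured compounds shown here, no measured step touches this position, and the one step that exists elsewhere gives no readable size. Nothing in the numbers shown points to a step beyond the scatter in this assay in either direction; the expectation is that compound 4 likewise reaches a limit. Compound 4 is accordingly estimated at 60000 nM, with a range from 20000 nM to 200000 nM. The step this estimate implies, a step that the limit leaves unreadable from compound 1 to compound 4, is expected to sit within the scatter.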

Compound 4, concentration lethal to 50% of the cells: > 32500 nM
Compound 4 ended at the assay's limit (the forecaster's own chance of this, stated with the estimate: 80%); the middle value does not contradict the limit.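

No size can be read for the change between compound 1 and compound 4 in this assay, as both values are limits of the assay and not numbers: the limit of > 32500 nM in this assay, at which 3 of the 4 values shown sit.

The compounds shown leave open whether any aryl group on the urea or amide of this series gives a readable number in this assay.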